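Ureas at the limit: from compound 1 to compound 3

This account rests on a few compounds, and the source may have more. Where it says the series, first, only, none or still open, it means among the compounds named here.

Measured so far:
compound 1 `Cc1ncncc1NC(=O)Nc1cnc(-n2nccn2)c(Cl)c1`: > 20000 nM
compound 2 `CC(C)c1ncncc1NC(=O)Nc1cnc(-n2nccn2)c(Cl)c1`: > 20000 nM

In a functional assay on OCI-Ly3 cells (Homo sapiens) for antiproliferative activity (on this read-out higher numbers stand for an effect only at larger amounts of compound and lower numbers for an effect already at smaller amounts), compound 1 stands at > 20000 nM, which is a limit and not a number. Compound 2 gives > 20000 nM, which is also a limit. The whole picture so far is the limit of > 20000 nM in this assay, at which 2 of the 2 values shown sit.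

Compound 3 `Cc1cc(C)c(NC(=O)Nc2cnc(-n3nccn3)c(Cl)c2)cn1` keeps the core of compound 1 and changes the group on the amide-type nitrogen, with 4,6-dimethylpyridin-3-yl in place of 4-methylpyrimidin-5-yl on an amide-type nitrogen.

Within the data shown here, the one measured step bearing on this is a step that the two limits leave unreadable from compound 1 to compound 2. It concerns a different place on the molecule and offers no size to carry over. Because the limit of > 20000 nM in this assay, at which 2 of the 2 values shown sit, no active reference point exists, so a large step in this assay is not expected. Compound 3 is expected to remain at or close to the limit, with a modest shift towards effect at smaller amounts as the only likely direction.

The expected step is an at least 1.3-fold lower number from compound 1 to compound 3 (0.12 log units; that floor lies within the scatter). For compound 3 the estimate is 15000 nM, with an expected range from 3000 nM to 20000 nM.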

Compound 3, half-maximal effective concentration: > 20000 nM
Compound 3: a limit, no number (the forecaster's own chance of this, stated with the estimate: 55%); middle value at least 1.3-fold (0.12 log units) from the limit.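

In this assay compound 3 gives > 20000 nM, which is a limit and not a number, so no step can be read between compound 1 and compound 3. The compounds shown leave open whether any change on the shared core gives a measurable value in this assay: the limit of > 20000 nM in this assay, at which 3 of the 3 values shown sit.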